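The source may hold more compounds than are shown below. What is called first, only, known or untested is meant among the compounds shown, and "the series" means these compounds.

Measured so far:
compound 1 `Cc1nn(-c2nc(-c3ccc(Cl)c(Cl)c3)c(SC(C)C)s2)c(C(=O)O)c1-c1cncnc1` — 22000 nM
compound 2 `Cc1cc(-c2c(C)nn(-c3nc(-c4ccc(Cl)c(Cl)c4)c(SC(C)C)s3)c2C(=O)O)cc(C)n1` — 580 nM
compound 3 `Cc1nn(-c2nc(-c3ccc(Cl)c(Cl)c3)c(SC(C)C)s2)c(C(=O)O)c1-c1cccnc1` — 12000 nM

In a functional assay on BJAB cells (Homo sapiens) for antiproliferative activity, with a stated time of 4 days (a lower number here means that less compound is needed, a higher number that more compound is needed for the effect), compound 1 gives 22000 nM, the highest number of the three. Compound 3 is nearest, with a 1.8-fold lower number from compound 1 to compound 3 (0.26 log units; within the scatter); compound 2 is furthest, with a 38-fold lower number from compound 1 to compound 2 (1.58 log units; beyond the scatter). Compound 4 `Cc1nn(-c2nc(-c3ccc(Cl)c(Cl)c3)c(SC(C)C)s2)c(C(=O)O)c1-c1ccc(Cl)cc1` has not yet been measured. Its change from compound 1 is 4-chlorophenyl in place of pyrimidin-5-yl on an aromatic carbon.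

Both measured steps from compound 1 exchange the same group at the same place, so both bear on this one. The exchange for pyridin-3-yl stays within the scatter; the exchange for 2,6-dimethylpyridin-4-yl is large. For the measured compounds named here, neither entering group is 4-chlorophenyl, and no compound here carries a ring of carbon only at this place, so the direction can only be read loosely from the two steps: each moves downward, one barely and one strongly. A downward step of intermediate size is therefore expected for compound 4, a 4.4-fold lower number from compound 1 to compound 4 (0.64 log units; beyond the scatter), with wide uncertainty. The estimate for compound 4 is 5000 nM, between 1500 nM and 16000 nM.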

Compound 4, half-maximal effective concentration: 2500 nM
Compound 4: the middle estimate sits 2.0-fold (0.30 log units) above what was measured, within the range that was stated.
By their numbers in this assay, from the lowest: compound 2; then compound 4; then compounds 3 and 1 (each within the scatter of the next).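

In this assay, the first ring of carbon only at this place, 4-chlorophenyl, gives an 8.8-fold lower number from compound 1 to compound 4 (0.94 log units; beyond the scatter) and a 4.8-fold lower number from compound 3 to compound 4 (0.68 log units; beyond the scatter), so replacing either nitrogen-containing ring shown with this group lowers the number beyond the scatter. Loss of ring nitrogen does not settle the order on its own: compound 2 goes against that reading, since its 2,6-dimethylpyridin-4-yl keeps a ring nitrogen and still gives the lower number, with a 4.3-fold higher number from compound 2 to compound 4 (0.63 log units; beyond the scatter). No measurement at hand explains these steps.

The compounds shown leave open how much of the step from pyrimidin-5-yl belongs to the carbon ring and how much to its chlorine, which an unsubstituted phenyl would separate. Likewise open, on these data alone, is what the two methyl groups of compound 2 contribute, which pyridin-4-yl without methyl groups would test.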